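Lengthening the linker from compound 3 to compound 4

The source may hold more compounds than are shown below. What is called first, only, known or untested is meant among the compounds shown, and "the series" means these compounds.

Within the data shown here, compound 3 `COc1cc2ncnc(Nc3ccc(F)c(Cl)c3)c2cc1OCCn1c([N+](=O)[O-])cnc1C` is one of three compounds measured in a functional assay on HT-29 cells (Homo sapiens) for cytotoxicity, read by sulforhodamine B assay, with a stated time of 72 h; on this read-out lower numbers stand for stronger inhibition and higher numbers for weaker inhibition. In this assay compound 3 gives > 50000 nM, which is a limit of the assay and not a number. Compound 1 `COc1cc2ncnc(Nc3ccc(F)c(Cl)c3)c2cc1OCCn1ccnc1[N+](=O)[O-]` likewise gives > 50000 nM, again a limit. Compound 2 `COc1cc2ncnc(Nc3ccc(F)c(Cl)c3)c2cc1OCCCCn1ccnc1[N+](=O)[O-]` gives 2210 nM. The step of an at least 22-fold lower number from compound 1 to compound 2 (1.35 log units; beyond the scatter) is the only one that can be read in full; the step that the two limits leave unreadable from compound 1 to compound 3 stays unreadable, and the step of an at least 22-fold higher number from compound 2 to compound 3 (1.35 log units; beyond the scatter) is the mirror of the first. Two of the three values sit at the limit of > 50000 nM in this assay, at which 2 of the 3 values shown sit.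

Compound 4 `COc1cc2ncnc(Nc3ccc(F)c(Cl)c3)c2cc1OCCCn1c([N+](=O)[O-])cnc1C` differs from compound 3 by (2-methyl-5-nitro-1H-imidazol-1-yl)methyl in place of 2-methyl-5-nitro-1H-imidazol-1-yl on a saturated chain carbon, two bonds along the chain from an oxygen on an aromatic ring. The change is of the same kind as the lengthening from compound 1 to compound 2, though shorter by one chain carbon. Compound 3 stands at a limit, so the size of any step from it cannot be anchored. Compound 4 is nevertheless expected to show a lower number in this assay, the estimated step being an at least 3.3-fold lower number from compound 3 to compound 4 (0.52 log units; beyond the scatter). Compound 4 is estimated at 15000 nM, within 3000 nM to 60000 nM.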

Compound 4, half-maximal inhibitory concentration: 23200 nM
For compound 4 the middle estimate is 1.5-fold (0.19 log units) below the measured one; low and high end bracket the measured number.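

Adding one chain carbon at this position moves the 2-methyl-5-nitro-1H-imidazol-1-yl group off the limit in this assay, with an at least 2.1-fold lower number from compound 3 to compound 4 (0.33 log units; beyond the scatter), so a lower number on lengthening is no longer confined to the 2-nitro-1H-imidazol-1-yl group. Among these compounds, the one step between two real numbers is a 10-fold higher number from compound 2 to compound 4 (1.02 log units; beyond the scatter), but chain and imidazole group change together there, so neither can be credited alone. There is also an at least 2.1-fold lower number from compound 1 to compound 4 (0.33 log units; beyond the scatter), but this step and the first are bounds only: the limit of > 50000 nM in this assay, at which 2 of the 4 values shown sit.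

From the compounds shown here alone, it remains open whether a chain longer than either of these would lower the number further for the 2-methyl-5-nitro-1H-imidazol-1-yl group. Going by these compounds, it is also open whether an amine in place of the nitro group would keep any of these numbers.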